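The source may report more compounds than this note shows. Statements on the series, on what has been measured and on what is new or still open speak of the compounds shown alone.

Measured compounds:
compound 1 `Cc1cc(C(=O)Nc2ccc(F)cc2)nn1Cc1cc(Cl)ccc1OCc1ccccc1` gives 79.4 nM in an assay on CHO-K1 cells for displacement of a labelled ligand from prostaglandin E2 receptor EP1 subtype (Homo sapiens); a higher number here means a weaker inhibitor, a lower number a stronger inhibitor
compound 2 `Cc1cc(C(=O)NCc2cccnc2)nn1Cc1cc(Cl)ccc1OCc1ccccc1` gives 50.1 nM in this assay

Compound 2 has the lower of the two numbers, but the step of a 1.6-fold lower number from compound 1 to compound 2 (0.20 log units; within the scatter) lies within the scatter, so the two compounds cannot be told apart on these data. Among the compounds with values here, the only measured step concerns the group on the amide nitrogen of a carboxamide that sits on the shared core, and that step changed little.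

Compound 3 `Cc1cc(NC(=O)CC(C)(C)C)nn1Cc1cc(Cl)ccc1OCc1ccccc1` has not yet been measured. It differs from compound 2 as follows: (neopentylcarbonyl)amino in place of ((pyridin-3-yl)methyl)carbamoyl on an aromatic carbon. In compound 2 the carbonyl is attached to the core and the nitrogen carries the side group; in compound 3 the nitrogen is attached to the core and the carbonyl carries the neopentyl chain. Within the data shown here, no measured step touches this change, and the one step that is known, a 1.6-fold lower number from compound 1 to compound 2 (0.20 log units; within the scatter), speaks only to the side group and was within the scatter. The direction of the step in this assay therefore cannot be read from the data, and the expected step of a 2.6-fold higher number from compound 2 to compound 3 (0.41 log units; beyond the scatter) is set near no change with a wide range. Compound 3 is estimated at 130 nM, between 25 nM and 700 nM.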

Compound 3, half-maximal inhibitory concentration: 10 nM
Estimate against measurement, compound 3: 13-fold (1.11 log units) above, outside the stated range (below it).
By their numbers in this assay, from the lowest: compound 3; then compounds 2 and 1 (each within the scatter of the next).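

In this assay, (neopentylcarbonyl)amino in place of ((pyridin-3-yl)methyl)carbamoyl gives a 5.0-fold lower number from compound 2 to compound 3 (0.70 log units; beyond the scatter), and the same group in place of (4-fluorophenyl)carbamoyl gives a 7.9-fold lower number from compound 1 to compound 3 (0.90 log units; beyond the scatter). Both steps lie beyond the scatter and run the same way, so this aromatic carbon responds to change in a way the earlier swap of side groups on the carboxamide nitrogen did not show, and a carboxamide joined through its carbonyl is not needed here for a low number, since a group joined through its nitrogen and carrying an open chain with no ring gives the lowest number of the three. No measurement shown speaks to why the number falls.

Each step changes the direction of the amide and the side group at once, so the compounds shown leave open how much of the change belongs to each. Also open, from the compounds shown here alone, is whether a (pyridin-3-yl)acetylamino group, with the earlier ring on the reversed amide, or a plain amine at this carbon would keep the number as low as that of compound 3.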